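A few compounds are considered here, and "the series" means these few. Any claim that something is new, unique, unknown or untested is made for them only; others in the source may bear on it.

Measured so far:
- compound 1, `CCN(CC)S(=O)(=O)c1ccc(S(=O)(=O)N2CCC[C@@H](C(=O)NC3CN(C(=O)OC(C)(C)C)C3)C2)cc1`: > 10000 nM
- compound 2, `CCOC(=O)[C@@H]1CCC[C@H](S(=O)(=O)c2ccc(S(=O)(=O)N(CC)CC)cc2)C1`: > 10000 nM
- compound 3, `CCOC(=O)N1CCC[C@H](S(=O)(=O)c2ccc(S(=O)(=O)N(CC)CC)cc2)C1`: > 10000 nM

In a functional assay on MIA PaCa-2 cells (Homo sapiens) for inhibition, read by MTT assay, with a stated time of 3 days (a higher number here means a weaker inhibitor, a lower number a stronger inhibitor), compound 1 gives > 10000 nM, which is a limit of the assay and not a number. Compound 2 gives > 10000 nM in this assay, again a limit. Compound 3 gives > 10000 nM in this assay, likewise a limit. Among the compounds with values here, compound 1 thus stands on (the limit of > 10000 nM in this assay, at which 3 of the 3 values shown sit); nothing measured yet resolves into a number, and no step between two measured compounds can be sized.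

The next compound, compound 4 with structure `CCN(CC)S(=O)(=O)c1ccc(S(=O)(=O)N2CCC[C@@H](C(=O)N3CCN(c4nc(C)no4)CC3)C2)cc1`, keeps the shared core of compound 1 and differs from it in one place: 4-(3-methyl-1,2,4-oxadiazol-5-yl)piperazin-1-yl in place of (1-(tert-butoxycarbonyl)azetidin-3-yl)amino on a carbonyl carbon. Within the data shown here, with no measured step available and three values all sitting on the limit, there is no basis for expecting a step in either direction beyond the scatter; the working expectation is that the reading stays at or near the limit, the expected step being a number no higher from compound 1 to compound 4 (the limit leaves the size open). For compound 4 in this assay the estimate is 10000 nM, with a range from 2500 nM to 40000 nM, and a substantial chance that only a limit is reported.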

Compound 4, half-maximal inhibitory concentration: > 10000 nM
Compound 4 was reported as a limit; the forecaster's own chance of this, stated with the estimate: 65%; the middle value lies on the limit itself.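

In this assay compound 4 gives > 10000 nM, a limit and not a number. Within the data shown here, with compound 1 also reported only as a limit, no step between compound 1 and compound 4 can be read. The compounds shown leave open which change, if any, would give a resolved number in this assay, since every reading so far is the same: the limit of > 10000 nM in this assay, at which 4 of the 4 values shown sit.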